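The compounds below may be only part of what the source reports. "The series", "measured", "known", "first", "only" and "open" are said of these compounds alone.

Measured so far:
- compound 1, `NN(c1ccccc1)c1nnc(-c2ccccc2Cl)s1`: > 100 mg/kg in a functional assay on the whole organism with Mus musculus as the target, with a stated time of 1 h; on this read-out higher numbers stand for an effect only at larger amounts of compound and lower numbers for an effect already at smaller amounts
- compound 2, `CC(C)N(N)c1nnc(-c2ccccc2-c2ccccc2)s1`: > 100 mg/kg in this assay

In this assay compound 1 gives only > 100 mg/kg, which is a limit of the assay and not a number. In this assay compound 2 likewise gives only > 100 mg/kg, again a limit of the assay rather than a number. So compound 2 stands at the limit of > 100 mg/kg in this assay, at which 2 of the 2 values shown sit; no measured number places it anywhere else.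

Compound 3, `NN(c1ccccc1)c1nnc(-c2ccccc2-c2ccccc2)s1`, has not yet been measured in this assay. It differs from compound 2 by phenyl in place of isopropyl on a nitrogen on an aromatic ring. Among the measured compounds shown here, no pair of measured compounds differs in one place, so no measured step gives a size for this change. For the measured compounds named here, the only guidance is that compound 2 and compound 1 both sit at the limit, and compound 1 already carries the phenyl group on that nitrogen. On that basis no step beyond the scatter is expected for compound 3 in this assay, and the most likely outcome is again a limit. The expected step from compound 2 to compound 3 is a step that the limit leaves unreadable from compound 2 to compound 3. Compound 3 is estimated at 150 mg/kg, with a range from 70 mg/kg to 400 mg/kg.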

Compound 3, dose for half-maximal effect: > 100 mg/kg
Compound 3: only a limit was reported; the forecaster's own chance of this, stated with the estimate: 75%; the middle value lies beyond the limit too.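

No new step can be read: compound 3 joins compound 1 and compound 2 at one limit of the assay, so the changes linking compound 3 to each of them have no readable size. All three sit together: the limit of > 100 mg/kg in this assay, at which 3 of the 3 values shown sit.

The compounds shown leave open which change to the shared core, if any, would give a measurable number in this assay.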